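A Smaller Propargyl Arm on the Sulfonamide Nitrogen

The source may hold more compounds than are shown below. What is called first, only, known or untested is meant among the compounds shown, and "the series" means these compounds.

Compound 1 `N#Cc1ccc(CN2c3ccccc3C(=O)N(Cc3ccccc3)S2(=O)=O)cc1` belongs to a small set of three measured compounds on a shared core. In a functional assay on MRC5 cells (Homo sapiens) (on this read-out higher numbers stand for lower toxicity in this test and lower numbers for higher toxicity in this test), compound 1 gives 62000 nM. Its nearest neighbour is compound 2 `N#Cc1ccc(CN2c3ccccc3C(OCc3ccccc3)=NS2(=O)=O)cc1`, which in this assay gives 62000 nM, no change at the digits shown and well within the scatter. Compound 3 `O=C1c2ccccc2N(Cc2ccccc2-c2ccccc2)S(=O)(=O)N1Cc1ccccc1-c1ccccc1` is reported only as a limit of the assay rather than as a number. In this assay compound 3 gives > 47000 nM. That limit is the limit of > 47000 nM in this assay, at which 1 of the 3 values shown sits.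

The unmeasured compound 4 `C#CCCN1c2ccccc2C(=O)N(Cc2ccccc2)S1(=O)=O` differs from compound 1 in one place: propargyl in place of 4-cyanophenyl on a saturated chain carbon bound to a sulfonamide nitrogen in a ring. Within the data shown here, no step between two measured compounds in this set maps onto this change, so nothing measured here sets its size or direction. The step in this assay from compound 1 to compound 4 is expected to be no change at the digits printed from compound 1 to compound 4 (within the scatter), that is, none beyond the scatter. Compound 4 is therefore estimated to sit near 62000 nM in this assay, with a range from 20000 nM to 150000 nM.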

Compound 4, half-maximal cytotoxic concentration: 77000 nM
Compound 4: the middle estimate sits 1.2-fold (0.09 log units) below what was measured, within the range that was stated.
By their numbers in this assay, from the lowest: compounds 1, 2 and 4 (each within the scatter of the next).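

In this assay, putting propargyl in place of 4-cyanophenyl on a saturated chain carbon bound to a sulfonamide nitrogen in a ring gives a 1.2-fold higher number from compound 1 to compound 4 (0.09 log units; within the scatter). Among these compounds, this is the first measured step at this position, and it shows that the read-out stays within the scatter when the aromatic ring and the nitrile both leave and only a small alkyne-bearing chain remains. Thus neither the aromatic ring nor the nitrile is needed at this position to keep the number where it stands in this set.

Compound 3 remains a limit of the assay and not a number: the limit of > 47000 nM in this assay, at which 1 of the 4 values shown sits.

The compounds shown leave open whether an amine or a carboxylic acid at this position would move the number beyond the scatter.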